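This account rests on a few compounds, and the source may have more. Where it says the series, first, only, none or still open, it means among the compounds named here.

Measured so far in an ADME assay on DU-145 cells (Homo sapiens) for cytotoxicity, read by MTT assay, with a stated time of 72 h; on this read-out lower numbers stand for stronger inhibition and higher numbers for weaker inhibition:

Compound 1 `COc1ccc(C2=C(c3cc(OC)c(OC)c(OC)c3)C(=O)C(O)C2)cc1`: > 100 ug/mL
Compound 2 `COC(=O)c1cc(C2=C(c3cc(OC)c(OC)c(OC)c3)C(=O)CC2O[SiH2]C(C)(C)C)ccc1OC`: > 100 ug/mL
Compound 3 `COc1cc(C2=C(c3ccc(OCC(=O)O)cc3)C(O)CC2=O)cc(OC)c1OC`: > 100 ug/mL

None of these three readings is a true number, because each is a limit of the assay. Compound 2 stands at > 100 ug/mL in this assay, and this is a limit. The whole set looks the same: the limit of > 100 ug/mL in this assay, at which 3 of the 3 values shown sit. The three compounds therefore cannot be ranked against one another.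

Compound 4 `COc1cc(C2=C(c3cc(C)c(OC)c(C)c3)C(O[SiH2]C(C)(C)C)CC2=O)cc(OC)c1OC` is the next to be tested. It keeps the shared core of compound 2 and changes one group on a double-bonded ring carbon, with 4-methoxy-3,5-dimethylphenyl in place of 4-methoxy-3-(methoxycarbonyl)phenyl on a double-bonded ring carbon.

For the measured compounds named here, no two measured compounds differ in just one place, so the data offer no measured step to use as a guide. Going by the values given here, with the limit of > 100 ug/mL in this assay, at which 3 of the 3 values shown sit, as the only evidence, no change beyond the usual scatter is expected, and no direction can be favoured. The estimated change is a number no higher from compound 2 to compound 4 (the limit leaves the size open). The most likely outcome is another limit rather than a number. For compound 4 the expected value is 100 ug/mL, with an estimated range from 30 ug/mL to 200 ug/mL.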

Compound 4, half-maximal inhibitory concentration: > 100 ug/mL
Compound 4: a limit, no number (the forecaster's own chance of this, stated with the estimate: 75%); the middle value lies on the limit itself.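

Compound 2 and compound 4 both give a limit rather than a number, so no step can be read between them, because every reading is the same limit: the limit of > 100 ug/mL in this assay, at which 4 of the 4 values shown sit. The compounds shown leave open how strongly any of them acts on these cells, and which groups on the shared core would give a true number.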